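Alkoxy chain length in two dithioacetal series

This account rests on a few compounds, and the source may have more. Where it says the series, first, only, none or still open, it means among the compounds named here.

Measured in an assay on membranes from lung (Cavia porcellus) for binding affinity to cysteinyl leukotriene receptor (Homo sapiens) (a higher number here means a weaker inhibitor, a lower number a stronger inhibitor), so far:
compound 1 `CCCCCCCCCCCOc1ccccc1C(SCCC(=O)O)SCCC(=O)O`: 287 nM
compound 2 `CCCCCCCCCOc1ccccc1C(SCCC(=O)O)SCCC(=O)O`: 4090 nM
compound 3 `CCCCCCCCCCCOc1cccc(C(SCCC(=O)O)SCCC(=O)O)c1`: 78 nM

Compound 3 stands lowest of the three, with compound 1 nearest and compound 2 furthest. The difference between the core of compound 1 and the core of compound 3 is not broken down here; the two have the same atoms joined differently.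

Within the core of compound 1, the change hydrogen in place of ethyl on a saturated chain carbon, nine bonds along the chain from an oxygen on an aromatic ring gave a 14-fold higher number from compound 1 to compound 2 (1.15 log units; beyond the scatter).

Compound 4 `CCCCCCCCCOc1cccc(C(SCCC(=O)O)SCCC(=O)O)c1` is not yet measured. It differs from compound 3 by hydrogen in place of ethyl on a saturated chain carbon, nine bonds along the chain from an oxygen on an aromatic ring, the same kind of change at the same printed place, on the other core. Because a 14-fold higher number from compound 1 to compound 2 (1.15 log units; beyond the scatter) was large, a step of similar direction and size is expected from compound 3, estimated as a 12-fold higher number from compound 3 to compound 4 (1.06 log units; beyond the scatter). This rests on a single precedent only. Compound 4 is therefore estimated at 900 nM, expected between 250 nM and 3500 nM in this assay.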

Compound 4, inhibition constant: 624 nM
The estimate for compound 4 lay 1.4-fold (0.16 log units) above the measured number; low and high end bracket the measured number.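

In this assay, hydrogen in place of ethyl on the second core gave an 8.0-fold higher number from compound 3 to compound 4 (0.90 log units; beyond the scatter), the same direction as on the core of compound 1. The two steps do not differ beyond what repeated measurement allows: the same change on two cores in this assay, a 14-fold higher number (1.15 log units; beyond the scatter) from compound 1 to compound 2 and an 8.0-fold higher number (0.90 log units; beyond the scatter) from compound 3 to compound 4, 1.8-fold (0.25 log units) apart, within the scatter of two such steps. This shows the change carrying over between these two cores for this one pair of chain lengths, but it does not show that the step would keep its size at other chain lengths or on other cores.

From the compounds shown here alone, how a longer chain, or a chain ending in a hydroxyl group or an amine, would behave on either core remains open. So does the effect of a tetrazole in place of a carboxylic acid.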